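Working notes: a propoxyphenyl isomer of compound 2

The source may report more compounds than this note shows. Statements on the series, on what has been measured and on what is new or still open speak of the compounds shown alone.

Compound 1 `CCOc1ccccc1/C=C/C(=O)c1ccc(OCCn2cc(CN3C(=O)/C(=C4\Nc5ccccc5\C4=N/O)c4ccccc43)nn2)cc1O` gives 2010 nM
Compound 2 `CCCOc1ccccc1/C=C/C(=O)c1ccc(OCCn2cc(CN3C(=O)/C(=C4\Nc5ccccc5\C4=N/O)c4ccccc43)nn2)cc1O` gives 2280 nM
Compound 3 `CCCOc1cccc(/C=C/C(=O)c2ccc(OCCn3cc(CN4C(=O)/C(=C5\Nc6ccccc6\C5=N/O)c5ccccc54)nn3)cc2O)c1` is not yet measured

For the measured compounds named here, in a functional assay on HepG2 cells (Homo sapiens) for inhibition, read by MTT assay, with a stated time of 72 h (on this read-out lower numbers stand for stronger inhibition and higher numbers for weaker inhibition), compound 2 (2280 nM) stands level with compound 1 (2010 nM), the only other measured compound. The next change, from compound 2 to compound 3, is a group of 10 heavy atoms (9 carbon, 1 oxygen; one six-membered aromatic ring of carbon only) in place of a group of 10 heavy atoms (9 carbon, 1 oxygen; one six-membered aromatic ring of carbon only), on a double-bonded chain carbon bound to a double-bonded chain carbon (the same atoms, joined differently). The 3-propoxyphenyl group of compound 3 sits on a double-bonded chain carbon bound to a double-bonded chain carbon.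

One measured step is available, a 1.1-fold higher number from compound 1 to compound 2 (0.05 log units; within the scatter) (a change on the saturated chain only). It bears on the new change only indirectly, since it does not alter how the group is joined. Going by the values given here, no measured pair covers a change of this kind, so the data favour no direction, and the range has to stay wide. No step beyond the scatter is expected in this assay. The expected step is a 1.0-fold lower number from compound 2 to compound 3 (0.02 log units; within the scatter) (an estimate with no favoured direction). The value expected for compound 3 is 2200 nM (estimated range 1000 nM to 5000 nM).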

Compound 3, half-maximal inhibitory concentration: 2950 nM
For compound 3 the middle estimate is 1.3-fold (0.13 log units) below the measured one; measured number inside the range.
By their numbers in this assay, from the lowest: compounds 1, 2 and 3 (each within the scatter of the next).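

In this assay, for the compounds shown here, the 3-propoxyphenyl group on a double-bonded chain carbon bound to a double-bonded chain carbon, made of the same atoms as the group it replaces but joined differently, gives a 1.3-fold higher number from compound 2 to compound 3 (0.11 log units; within the scatter), so at this position this rearrangement yields no step that can be read beyond the scatter. Set against the 2-ethoxyphenyl group, the same 3-propoxyphenyl group gives a 1.5-fold higher number from compound 1 to compound 3 (0.17 log units; within the scatter), which means the two groups cannot be told apart in this read-out, and the earlier step on the saturated chain did not test how the group is joined. No independent measurement bears on why these groups read alike.

From the compounds shown here alone, all three compounds carry an alkoxyphenyl group at this position, so the response to a phenyl ring bearing an amine or a carboxylic acid remains open, as does the response to an alkoxy chain longer than propoxy. Whether any change at this position can give a step beyond the scatter in this assay also remains unanswered by the compounds shown.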